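The source may report more compounds than this note shows. Statements on the series, on what has been measured and on what is new or still open speak of the compounds shown alone.

Of the compounds shown here, two have been tested so far: compound 1 `COCCCCCCCCCCCCCCC/C=C1/CC(CO)(COC(=O)C(C)(C)C)OC1=O` and compound 2 `COCCCCCCCCCCCCCCC/C=C1\CC(CO)(COC(=O)C(C)(C)C)OC1=O`, which share the same atoms and bonds. Among the compounds with values here, in a functional assay on CCRF-CEM cells (Homo sapiens) for antiproliferative activity (a lower number here means a stronger inhibitor of growth, a higher number a weaker inhibitor of growth), compound 2 gives 4.26 ug/mL, the only true number available. Compound 1 gives < 0.1 ug/mL, which is a limit of the assay and not a number.

Within the data shown here, the one measured step, an at least 42-fold higher number from compound 1 to compound 2 (1.62 log units; beyond the scatter), concerns the double bond alone. Its size should be read with the limit of < 0.1 ug/mL in this assay, at which 1 of the 2 values shown sits, and the fact that one of compounds 1 and 2 is drawn with a defined configuration and the other without, at the place where they differ in mind.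

The next compound, compound 3 `COCCCCCCCCCCC/C=C1\CC(CO)(COC(=O)C(C)(C)C)OC1=O`, keeps the double bond as drawn in compound 2 and changes the chain instead: methoxy in place of 4-methoxybutyl on a saturated chain carbon, ten or more bonds along the chain from a double-bonded chain carbon. Among the measured compounds shown here, no measured step touches this chain, so the large step at the double bond cannot be carried over to it. Going by these compounds, with nothing to set a direction, no step beyond the scatter is expected in this assay, although a move either way remains open. The best guide is therefore compound 2 at 4.26 ug/mL. The expected size of the change is a 1.1-fold lower number from compound 2 to compound 3 (0.03 log units; within the scatter). Compound 3 is estimated at 4 ug/mL, with an expected range of 1.2 ug/mL to 12 ug/mL.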

Compound 3, concentration for 50% growth inhibition: 0.701 ug/mL
For compound 3 the middle estimate is 5.7-fold (0.76 log units) above the measured one; measured number below the stated range.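

In this assay, the chain proves to matter even far from the double bond: a 6.1-fold lower number from compound 2 to compound 3 (0.78 log units; beyond the scatter). This step comes from methoxy in place of 4-methoxybutyl, and the two groups match in their counts of hydrogen-bond donors and acceptors and in carrying no net charge, so the difference printed for them lies in the heavy atoms that leave the chain. The information at hand bears on neither the limit nor the drawn configuration of this chain change, and so gives no explanation for the step.

With one step at this position, the compounds shown give two points and no trend, so it remains open whether the number keeps falling, levels off or rises with chains of other lengths, including a longer chain than that of compound 2. Also open, going by these compounds, are the effect of a different group at the chain end, such as an amine or a carboxylic acid in place of the methoxy, and whether the same chain change would act alike with the double bond drawn as in compound 1.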